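A few compounds are considered here, and "the series" means these few. Any claim that something is new, unique, unknown or untested is made for them only; others in the source may bear on it.

Series notes, benzamide end of the enone.

Compound 1 `O=C(Nc1cccc(/C=C/C(=O)c2nc3ccccc3[nH]2)c1)c1ccccc1` gives 8340 nM in a functional assay on 143B cells (Homo sapiens) for antiproliferative activity, read by MTT assay, with a stated time of 48 h; a higher number here means a weaker inhibitor, a lower number a stronger inhibitor. Compound 2 `O=C(/C=C/c1cccc(NC(=O)c2ccccc2Cl)c1)c1nc2ccccc2[nH]1` gives 3690 nM in this assay; the step of a 2.3-fold lower number from compound 1 to compound 2 (0.35 log units; beyond the scatter) is the only one in the set that goes beyond the scatter. Compound 3 `O=C(Nc1cccc(/C=C/C(=O)c2nc3ccccc3[nH]2)c1)c1ccc(Br)cc1` gives 7310 nM in this assay; it stands second highest of the three numbers, with compound 1 nearest (a 1.1-fold lower number from compound 1 to compound 3 (0.06 log units; within the scatter)) and compound 2 furthest (a 2.0-fold higher number from compound 2 to compound 3 (0.30 log units; within the scatter)), both of these within the scatter.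

Compound 4 `Cc1cccc(C(=O)Nc2cccc(/C=C/C(=O)c3nc4ccccc4[nH]3)c2)c1` is not yet measured in this assay. Its change from compound 3 is 3-methylphenyl in place of 4-bromophenyl on a carbonyl carbon. Among the measured compounds shown here, two measured steps bear on it: the exchange of one aromatic group for another on the same carbonyl carbon, a 2.0-fold higher number from compound 2 to compound 3 (0.30 log units; within the scatter), and the substituent change on that ring, a 1.1-fold lower number from compound 1 to compound 3 (0.06 log units; within the scatter); neither leaves the scatter. Nothing in the set says how a methyl on the ring behaves, so the expectation for compound 4 in this assay rests on those two near-flat steps and is a step of no size beyond the scatter, a 1.0-fold lower number from compound 3 to compound 4 (0.02 log units; within the scatter). Compound 4 is therefore estimated at 7000 nM in this assay, with a range from 3500 nM to 14000 nM.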

Compound 4, half-maximal inhibitory concentration: 4880 nM
Beside the measured number, compound 4's estimate is 1.4-fold (0.16 log units) above it; low and high end bracket the measured number.
By their numbers in this assay, from the lowest: compounds 2, 4, 3 and 1 (each within the scatter of the next, the first and the last beyond it).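

In this assay, the 3-methylphenyl group on the carbonyl carbon does not separate from either halogen-bearing ring, with the exchange for 4-bromophenyl (a 1.5-fold lower number from compound 3 to compound 4 (0.18 log units; within the scatter)) and for 2-chlorophenyl (a 1.3-fold higher number from compound 2 to compound 4 (0.12 log units; within the scatter)) both staying within the scatter. Methyl in place of hydrogen on the ring (a 1.7-fold lower number from compound 1 to compound 4 (0.23 log units; within the scatter)) also stays within the scatter, so compound 4 adds a non-halogen substituent to the series without adding a second step beyond the scatter. No measurement at hand accounts for these small steps.

As far as these compounds go, all four compounds carry a carbon-only aromatic ring on this carbonyl carbon, so it remains open whether an amine, a carboxylic acid or a longer chain on that ring would give a step beyond the scatter. Among the compounds shown here, it also remains open whether the one step beyond the scatter, the chloro step from compound 1 to compound 2, would recur with 2-methylphenyl on the same carbonyl carbon.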